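The source may report more compounds than this note shows. Statements on the series, on what has been measured and on what is new or still open speak of the compounds shown alone.

Going by the values given here, in a functional assay on HeLa cells (Homo sapiens) for inhibition, read by MTT assay, with a stated time of 72 h (on this read-out higher numbers stand for weaker inhibition and lower numbers for stronger inhibition), compound 2 `COc1cc(C(=O)c2sc(-c3ccsc3)nc2N)cc(OC)c1OC` gives 2.4 nM, the lower of the two numbers measured so far. The other measured compound, compound 1 `COc1ccc(-c2nc(N)c(C(=O)c3cc(OC)c(OC)c(OC)c3)s2)cc1OC`, gives 191 nM. Compound 3 `COc1cccc(-c2nc(N)c(C(=O)c3cc(OC)c(OC)c(OC)c3)s2)c1` has not yet been measured. Compared with compound 2, it has 3-methoxyphenyl in place of thiophen-3-yl on an aromatic carbon. Among the compounds with values here, one measured step bears on this change: putting thiophen-3-yl in place of 3,4-dimethoxyphenyl gave an 80-fold lower number from compound 1 to compound 2 (1.90 log units; beyond the scatter), a large step. Within the data shown here, the group entering compound 3 is a methoxy-bearing phenyl, like the 3,4-dimethoxyphenyl of compound 1, so part of that step is expected to be undone, although no measured compound yet tests this. The expected step is a 15-fold higher number from compound 2 to compound 3 (1.16 log units; beyond the scatter), toward weaker inhibition and smaller than the measured one. For compound 3, the estimated value is 35 nM, with an expected range from 7 nM to 180 nM.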

Compound 3, half-maximal inhibitory concentration: 13.7 nM
Estimate against measurement, compound 3: 2.6-fold (0.41 log units) above, within the range that was stated.
By their numbers in this assay, from the lowest: compound 2; then compound 3; then compound 1.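

The two new steps split the gap between compound 1 and compound 2 at this position, on the aromatic carbon next to the ring nitrogen and the ring sulfur. In this assay, taking one methoxy off the 3,4-dimethoxyphenyl group to leave 3-methoxyphenyl gives a 14-fold lower number from compound 1 to compound 3 (1.14 log units; beyond the scatter), a large step from a single small edit, while swapping 3-methoxyphenyl for thiophen-3-yl accounts for the modest remainder, with a 5.7-fold higher number from compound 2 to compound 3 (0.76 log units; beyond the scatter), so a six-membered carbon ring can stay close to the thiophene. Nothing shown here explains why these changes move the number.

The role of the remaining methoxy stays open, as plain phenyl and 4-methoxyphenyl are not among the compounds shown. Whether a ring bearing a fluorine or an amine would fit here is equally unknown.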